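The source may hold more compounds than are shown below. What is called first, only, known or untested is meant among the compounds shown, and "the series" means these compounds.

Working notes on the series, read in a functional assay on HCT-116 cells (Homo sapiens) for inhibition, read by CCK-8 assay, with a stated time of 48 h; on this read-out lower numbers stand for stronger inhibition and higher numbers for weaker inhibition. Compound 3 (`COc1cc(-c2ccnc3cc(-c4cn(C)c5ccccc45)nn23)cc(OC)c1OC`) gives 762 nM, the highest of the three numbers, against compound 1 (`COc1cc(-c2ccnc3cc(-c4ccc(C)c(C)c4)nn23)cc(OC)c1OC`) at 261 nM and compound 2 (`COc1cc(-c2ccnc3cc(-c4ccc5c(ccn5C)c4)nn23)cc(OC)c1OC`) at 39 nM. Compound 4 (`C=Cc1ccc(-c2cc3nccc(-c4cc(OC)c(OC)c(OC)c4)n3n2)cc1`) carries 4-vinylphenyl in place of 1-methyl-1H-indol-3-yl on an aromatic carbon. Among the compounds with values here, the closest precedent is a 2.9-fold higher number from compound 1 to compound 3 (0.47 log units; beyond the scatter), where 1-methyl-1H-indol-3-yl replaced 3,4-dimethylphenyl. The step of a 20-fold higher number from compound 2 to compound 3 (1.29 log units; beyond the scatter) shows how far the number can move when 1-methyl-1H-indol-3-yl is involved, though its partner group is less like 4-vinylphenyl. A modest step to a lower number is therefore expected in this assay, roughly reversing the first of these. The expected change is a 4.2-fold lower number from compound 3 to compound 4 (0.63 log units; beyond the scatter). Compound 4 is estimated at 180 nM, within an expected range of 50 nM to 600 nM.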

Compound 4, half-maximal inhibitory concentration: 1060 nM
The estimate for compound 4 lay 5.9-fold (0.77 log units) below the measured number; the measured number lies above the stated range.
By their numbers in this assay, from the lowest: compound 2; then compound 1; then compounds 3 and 4 (each within the scatter of the next).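

At this position, 4-vinylphenyl brings no gain over 1-methyl-1H-indol-3-yl: the step shows a 1.4-fold higher number from compound 3 to compound 4 (0.14 log units; within the scatter). The same group falls well short of 1-methyl-1H-indol-5-yl, with a 27-fold higher number from compound 2 to compound 4 (1.43 log units; beyond the scatter), and also short of 3,4-dimethylphenyl, with a 4.1-fold higher number from compound 1 to compound 4 (0.61 log units; beyond the scatter). Nothing available accounts for these differences.

Still open, on these data alone, is whether the low number of compound 2 survives with the unmethylated 1H-indol-5-yl. As far as these compounds go, it is also open how 4-aminophenyl or 4-carboxyphenyl would read in this place.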